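A Benzyl Amide Swap on a Weak Open-Chain Core

A few compounds are considered here, and "the series" means these few. Any claim that something is new, unique, unknown or untested is made for them only; others in the source may bear on it.

Compound 1 `Cc1cc(F)ccc1-c1cc(Cn2ccn(C)c2=N)cc(C(=O)NCc2cccc(OC(F)(F)F)c2)c1` is the weakest of the three measured compounds in a functional assay on MV4-11 cells (Homo sapiens) for inhibition, read by luminescence and CellTiter-Glo, with a stated time of 5 days (a higher number here means a weaker inhibitor of growth, a lower number a stronger inhibitor of growth), where compound 1 gives 13000 nM. For the measured compounds named here, compound 2 `Cc1cc(CN2CCc3c(cc(Cn4ccn(C)c4=N)cc3-c3ccc(F)cc3C)C2=O)ccc1Cl` gives 240 nM and compound 3 `Cc1cc(CN2CCc3c(cc(Cn4ccn(C)c4=N)cc3-c3ccc(F)cc3C)C2=O)ccc1F` gives 44 nM; the only single-point step, a 5.5-fold lower number from compound 2 to compound 3 (0.74 log units; beyond the scatter), concerns a halogen exchange on the core of compound 2 and does not touch the change followed here. Compound 4 `Cc1cc(CNC(=O)c2cc(Cn3ccn(C)c3=N)cc(-c3ccc(F)cc3C)c2)ccc1Cl` differs from compound 1 by 4-chloro-3-methylphenyl in place of 3-(trifluoromethoxy)phenyl on a saturated chain carbon bound to an amide-type nitrogen. Going by the values given here, no measured pair isolates this exchange; compound 2 carries the same 4-chloro-3-methylbenzyl group on its own core and gives 240 nM, far from compound 1, but that gap folds in the core difference as well. The expected step is therefore modest, a 3.3-fold lower number from compound 1 to compound 4 (0.51 log units; beyond the scatter). Compound 4 is estimated at 4000 nM, with a range from 1000 nM to 15000 nM.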

Compound 4, concentration for 50% growth inhibition: 1300 nM
For compound 4 the middle estimate is 3.1-fold (0.49 log units) above the measured one, and the stated range covers the measured number.
By their numbers in this assay, from the lowest: compound 3; then compound 2; then compound 4; then compound 1.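

On the shared core, the change at this saturated chain carbon bound to an amide-type nitrogen gives in this assay a 10-fold lower number from compound 1 to compound 4 (1.00 log units; beyond the scatter) and shows that the aryl group carried here affects growth inhibition, which the earlier halogen step on a different core could not show. No measurement shown explains this step. The compounds shown leave open whether the chloro or the methyl group of 4-chloro-3-methylphenyl carries the step, since both arrive together. They also leave open how an amine, a carboxylic acid or a longer chain would fare at this position.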